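A few compounds are considered here, and "the series" means these few. Any claim that something is new, unique, unknown or untested is made for them only; others in the source may bear on it.

Compound 1, `CCCCn1cc(C(=O)O)c(=O)c2cc(F)c(N3CCC(C(N)=O)CC3)cc21`, in an ADME assay on J774.1 cells (Mus musculus) for cytotoxicity, read by resazurin assay, with a stated time of 48 h (a lower number here means a stronger inhibitor, a higher number a weaker inhibitor), gives > 100000 nM, which is a limit of the assay and not a number.
Compound 2, `CCCCn1cc(C(=O)NCc2ccc([N+](=O)[O-])cc2)c(=O)c2cc(F)c(N3CCC(C(N)=O)CC3)cc21`, gives > 100000 nM, again a limit rather than a number.
Compound 3, `CCCCn1cc(C(=O)NCc2ccc(O)cc2)c(=O)c2cc(F)c(N3CCC(C(N)=O)CC3)cc21`, gives 41600 nM.

Compound 1 therefore stands at the edge of what this assay can report, sharing the limit of > 100000 nM in this assay, at which 2 of the 3 values shown sit, with one other compound. Compound 4, `CCCCn1cc(C(=O)O)c(=O)c2cc(F)c(N3CCCCC3)cc21`, differs from compound 1 by hydrogen in place of carbamoyl on a saturated ring carbon. For the measured compounds named here, none of the measured steps touches that saturated ring carbon: a step that the two limits leave unreadable from compound 1 to compound 2 and an at least 2.4-fold lower number from compound 1 to compound 3 (0.38 log units; beyond the scatter) alter the group on the carbonyl carbon, and an at least 2.4-fold lower number from compound 2 to compound 3 (0.38 log units; beyond the scatter) swaps a group on the aromatic carbon. What they show is that the shared core can sit at the limit with two different groups on the carbonyl and move at least modestly with a third, while the piperidine end stays untouched throughout. Going by the values given here, with no measured step at the saturated ring carbon, no shift beyond the scatter is expected from removing the carbamoyl, and because compound 1 sits at the limit of > 100000 nM in this assay, at which 2 of the 3 values shown sit, compound 4 is expected to come back as a limit too. Compound 4 is estimated at 150000 nM, between 50000 nM and 500000 nM. This amounts to an expected step that the limit leaves unreadable from compound 1 to compound 4.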

Compound 4, half-maximal inhibitory concentration: 93000 nM
Compound 4: the middle estimate sits 1.6-fold (0.21 log units) above what was measured; the range from low to high includes it.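

For the compounds shown here, this is the first change at the saturated ring carbon, and replacing 4-carbamoylpiperidin-1-yl with piperidin-1-yl in this assay gives an at least 1.0-fold lower number from compound 1 to compound 4 (0.03 log units; that floor lies within the scatter). The step therefore does not establish a real drop, although compound 4 does give a measured number, so the piperidine end can now be tied to a readable value rather than only to an assay limit. How large the step truly is stays unknown because compound 1 carries a limit and not a number: the limit of > 100000 nM in this assay, at which 2 of the 4 values shown sit.

The compounds shown leave open whether a different group on this ring carbon, such as an amine, a carboxylic acid or a methyl group, would move the number beyond the scatter, since only carbamoyl and hydrogen appear there. They also leave open whether taking away the carbamoyl would have a readable effect when the carbonyl carbon carries the (4-hydroxybenzyl)amino group of compound 3, which gives 41600 nM and so offers a number, not a limit, to start from.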